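The source may report more compounds than this note shows. Statements on the series, on what has been measured and on what is new or still open speak of the compounds shown alone.

Of the compounds shown here, three sharing one core have been tested in a functional assay on HEK293 cells for positive allosteric modulation of metabotropic glutamate receptor 5 (Rattus norvegicus), read by fluorescence and calcium flux; on this read-out higher numbers stand for larger maximal responses and lower numbers for smaller maximal responses. Compound 1 `C[C@@H](NC(=O)c1ccc(C#Cc2ccccc2)cn1)C(C)(C)O` gives 60.9%. Compound 2 `C[C@@H](NC(=O)c1ccc(C#Cc2cc(F)cc(F)c2)cn1)C(C)(C)O` gives 61.6%. Compound 3 `Cc1ccccc1C#Cc1ccc(C(=O)N[C@H](C)C(C)(C)O)nc1` gives 59.9%. The steps among them are small: a number 0.7 percentage points higher from compound 1 to compound 2 (within the scatter), a number 1 percentage points lower from compound 1 to compound 3 (within the scatter) and a number 1.7 percentage points lower from compound 2 to compound 3 (within the scatter). On the numbers alone compound 3 stands lowest of the three, yet both its steps to the others lie within the scatter, so the three compounds cannot be told apart in this assay.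

Compound 4 `Cc1nc(C#Cc2ccc(C(=O)N[C@H](C)C(C)(C)O)nc2)cs1` is the next compound, not yet measured. 2-methyl-1,3-thiazol-4-yl in place of 2-methylphenyl on a triple-bonded carbon

Within the data shown here, the steps that bear on this change are those that already swapped the group on the triple-bonded carbon, from compound 1 to compound 2 and from compound 2 to compound 3; both stayed within the scatter. Hence no step beyond the scatter is expected here, and the estimated change is a number 0.1 percentage points higher from compound 3 to compound 4 (within the scatter). Compound 4 is expected to give 60%, most likely between 50% and 70%.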

Compound 4, largest response reached (reported as efficacy), in percent of the reference or control that the assay uses: 66.6%
Compound 4: the middle estimate sits 6.6 percentage points below what was measured; low and high end bracket the measured number.
By their numbers in this assay, from the lowest: compounds 3, 1, 2 and 4 (each within the scatter of the next).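

In this assay the entry of 2-methyl-1,3-thiazol-4-yl on the triple-bonded carbon gives a number 6.7 percentage points higher from compound 3 to compound 4 (within the scatter) and a number 5 percentage points higher from compound 2 to compound 4 (within the scatter) and a number 5.7 percentage points higher from compound 1 to compound 4 (within the scatter) so compound 4 cannot be told apart from the other three. Among these compounds, the earlier compounds carried only six-membered aromatic rings of carbon here, so this is the first sign that a five-membered aromatic ring with 2 hetero atoms and 2 hydrogen-bond acceptors is also compatible with a maximal response in the same range. No measurement is available that would explain the size of these steps.

Going by these compounds, what remains open is whether this position would keep that response with a group of a different kind on the triple-bonded carbon, such as an amine, a carboxylic acid or a longer alkyl chain.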